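This account rests on a few compounds, and the source may have more. Where it says the series, first, only, none or still open, it means among the compounds named here.

Measured so far:
compound 1 `C=CC1=C(C(=O)NCc2ccccc2)C(c2ccc(OC)c(OC)c2)OC1`; in a functional assay on QGY7701 cells (Homo sapiens) for cytotoxicity, read by MTT assay, with a stated time of 24 h (a higher number here means a weaker inhibitor, a lower number a stronger inhibitor), compound 1 gives > 100000 nM, which is a limit of the assay rather than a number.
compound 2 `C=CC1=C(C(=O)NCCC)C(c2ccc(OC)c(OC)c2)OC1`; in this assay compound 2 gives > 100000 nM, again a limit and not a number.
compound 3 `C=CC1=C(C(=O)NCc2ccc(C)cc2)C(c2ccc(OC)c(OC)c2)OC1`; in this assay compound 3 gives 69100 nM.

Compound 3 is thus the only one of the three with a measured number; the other two sit at the limit described by the limit of > 100000 nM in this assay, at which 2 of the 3 values shown sit. The step of an at least 1.4-fold lower number from compound 1 to compound 3 (0.16 log units; that floor lies within the scatter) and the step of an at least 1.4-fold lower number from compound 2 to compound 3 (0.16 log units; that floor lies within the scatter) both carry only a floor that lies within the scatter, and the step that the two limits leave unreadable from compound 1 to compound 2 cannot be read at all. All three measured compounds vary only the group hanging on the amide nitrogen, and every one of them is a very weak inhibitor.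

Compound 4 `C=CC1=C(C(=O)O)C(c2ccc(OC)c(OC)c2)OC1` differs from compound 3 by hydroxy in place of (4-methylbenzyl)amino on a carbonyl carbon. Within the data shown here, no measured step touches this part of the molecule, so the three compounds give no direct guidance; they show only that the whole series sits at or near the limit. With the amide removed altogether, a value at or above the limit in this assay seems at least as likely as a number.

Compound 4 is therefore expected to give about 150000 nM, estimated between 50000 nM and 500000 nM. The expected step of a 2.2-fold higher number from compound 3 to compound 4 (0.34 log units; beyond the scatter) is small and, if anything, toward a weaker inhibitor.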

Compound 4, half-maximal inhibitory concentration: > 100000 nM
Compound 4 was reported as a limit; the forecaster's own chance of this, stated with the estimate: 70%; the middle value does not contradict the limit.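

Unlike the earlier steps, which varied only the group on the amide nitrogen, this change removes the amide itself and leaves a carboxylic acid on the carbonyl carbon, and in this assay it gives an at least 1.4-fold higher number from compound 3 to compound 4 (0.16 log units; that floor lies within the scatter). That floor does not establish a real loss, but it does show that stripping away the whole (4-methylbenzyl)amino group, aromatic ring included, gives no sign of a stronger inhibitor. The steps from compound 1 and from compound 2 to compound 4 cannot be read, as both ends of each are limits, and the acid now joins the larger part of the series at that same limit: the limit of > 100000 nM in this assay, at which 3 of the 4 values shown sit.

From the compounds shown here alone, how much weaker compound 4 really is than compound 3 stays open, as the limit gives only a floor for the step. Also open, going by these compounds, is whether other groups on this carbonyl carbon, such as a methyl ester or an unsubstituted amide, would give a measured number, and whether a longer chain on the amide nitrogen would move the series away from the limit.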